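This account rests on a few compounds, and the source may have more. Where it says the series, first, only, none or still open, it means among the compounds named here.

Compound 1 `O=C(CCCCCCc1ccccc1)c1nncs1` — in an assay on HEK-293T cells for inhibition of diacylglycerol lipase-alpha (Homo sapiens), read by colorimetric assay (on this read-out lower numbers stand for stronger inhibition and higher numbers for weaker inhibition), compound 1 gives > 10000 nM, which is a limit of the assay and not a number.
Compound 2 `O=C(CCCCCCc1ccccc1)c1ncno1` — in this assay compound 2 gives > 10000 nM, again a limit of the assay.
Compound 3 `CSc1cnc(C(=O)CCCCCCc2ccccc2)o1` — in this assay compound 3 gives > 10000 nM, also a limit of the assay.

Compound 2 therefore stands only at a limit on the numbers shown, as do the two others (the limit of > 10000 nM in this assay, at which 3 of the 3 values shown sit). Compound 4 `O=C(CCCCCCc1ccccc1)c1nc(-c2cccc(Br)n2)no1` differs from compound 2 by 6-bromopyridin-2-yl in place of hydrogen on an aromatic carbon. Within the data shown here, the steps that bear on this change are those that alter the five-membered ring on the carbonyl carbon: a step that the two limits leave unreadable from compound 1 to compound 2 and a step that the two limits leave unreadable from compound 2 to compound 3, and likewise a step that the two limits leave unreadable from compound 1 to compound 3; all three are left unreadable by the two limits, so nothing measured here reports the size or direction of a change at this ring. Among the measured compounds shown here, the change to compound 4 is an addition of a larger group rather than an exchange of the ring, and no measured pair tests such an addition. Any expectation for compound 4 must therefore rest on the structural change alone, and the estimate is correspondingly wide. Compound 4 is expected at 1500 nM, within 100 nM to 20000 nM. The expected step from compound 2 to compound 4 is an at least 6.6-fold lower number from compound 2 to compound 4 (0.82 log units; beyond the scatter).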

Compound 4, half-maximal inhibitory concentration: 2040 nM
Beside the measured number, compound 4's estimate is 1.4-fold (0.13 log units) below it, and the stated range covers the measured number.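

In this assay, 6-bromopyridin-2-yl in place of hydrogen on the aromatic carbon between two ring nitrogen atoms gives an at least 4.9-fold lower number from compound 2 to compound 4 (0.69 log units; beyond the scatter), so this position accepts a large aromatic group and the change registers in the assay. Among these compounds, the three steps among compounds 1, 2 and 3, all exchanges of the five-membered ring on the carbonyl carbon, cannot be read, which leaves this as the only readable step here. Compound 4 is also the only compound shown with a number rather than a limit, and the other three share that limit: the limit of > 10000 nM in this assay, at which 3 of the 4 values shown sit.

The compounds shown do not separate the part played by the bromine from that of the pyridine ring; a plain pyridin-2-yl or a phenyl on this carbon would do so. On these data alone, whether the phenyl-ended chain on the carbonyl can be shortened with this group in place also stays open.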